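The source may report more compounds than this note shows. Statements on the series, on what has been measured and on what is new or still open speak of the compounds shown alone.

Of the compounds shown here, two of a shared core have been measured so far. Compound 1, `COc1ccc(-c2cc(COC(Cc3cn(C4CCN(Cc5ccc([N+](=O)[O-])cc5)CC4)nn3)c3ccc(Br)cc3)on2)cc1`, and compound 2, `N#Cc1ccc(-c2cc(COC(Cc3cn(C4CCN(Cc5ccc([N+](=O)[O-])cc5)CC4)nn3)c3ccc(Br)cc3)on2)cc1`, differ only in one group on an aromatic carbon. In a functional assay on MCF7 cells (Homo sapiens) for cytotoxicity, with a stated time of 48 h (a higher number here means a weaker inhibitor, a lower number a stronger inhibitor), compound 1 gives 4000 nM, and in the same assay compound 2 gives 3000 nM. The step of a 1.3-fold lower number from compound 1 to compound 2 (0.12 log units; within the scatter) does not rise above the scatter, so compound 2 stands alongside compound 1 without a clear distinction between the two.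

Compound 3, `O=[N+]([O-])c1ccc(CN2CCC(n3cc(CC(OCc4cc(-c5cccc(F)c5)no4)c4ccc(Br)cc4)nn3)CC2)cc1`, has not yet been measured. It differs from compound 2 as follows: 3-fluorophenyl in place of 4-cyanophenyl on an aromatic carbon. For the measured compounds named here, the only measured step that bears on this change is the one at the same place, a 1.3-fold lower number from compound 1 to compound 2 (0.12 log units; within the scatter), which swapped one group for another on that aromatic carbon without a shift beyond the scatter. There is therefore no basis for expecting a large move in either direction; a step of about a 1.2-fold higher number from compound 2 to compound 3 (0.07 log units; within the scatter) is expected, which stays within the scatter. On that ground compound 3 is estimated at 3500 nM in this assay, with a likely range from 1500 nM to 8000 nM.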

Compound 3, half-maximal inhibitory concentration: 8000 nM
The estimate for compound 3 lay 2.3-fold (0.36 log units) below the measured number, within the range that was stated.
By their numbers in this assay, from the lowest: compounds 2, 1 and 3 (each within the scatter of the next, the first and the last beyond it).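

In this assay, the aromatic carbon next to the ring nitrogen of the five-membered ring now shows its first step beyond the scatter, a 2.7-fold higher number from compound 2 to compound 3 (0.43 log units; beyond the scatter), so the group held there can change the result, although only modestly. The same 3-fluorophenyl group compared with 4-methoxyphenyl gives a 2.0-fold higher number from compound 1 to compound 3 (0.30 log units; within the scatter), so the change is clear only against 4-cyanophenyl and does not set compound 3 apart from both earlier compounds. Nothing available here explains the shift between compound 2 and compound 3.

Going from 4-cyanophenyl to 3-fluorophenyl changes both the group on the phenyl ring and its place on that ring, so this single step cannot show which of the two matters; 4-fluorophenyl and 3-cyanophenyl would help separate them. As far as these compounds go, how a plain phenyl, or a phenyl carrying an amine or a carboxylic acid, would behave at this position in this assay also remains open.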